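Ester size in the cytotoxicity series: ethoxy to isopropoxy

This account rests on a few compounds, and the source may have more. Where it says the series, first, only, none or still open, it means among the compounds named here.

In an ADME assay on HeLa cells (Homo sapiens) for cytotoxicity, read by MTT assay, with a stated time of 2 days (on this read-out lower numbers stand for higher toxicity in this test and higher numbers for lower toxicity in this test), compound 2 (`CCOC(=O)c1ccc2ccc(Oc3ccnc(C(=O)NC)c3)cc2c1`) gives 13200 nM as the lower of two numbers, while compound 1 (`CNC(=O)c1cc(Oc2ccc3ccc(C(=O)OC)cc3c2)ccn1`) gives 33800 nM as the higher. The unmeasured compound 3 (`CNC(=O)c1cc(Oc2ccc3ccc(C(=O)OC(C)C)cc3c2)ccn1`) differs from compound 2 by a single change (methyl in place of hydrogen on a saturated chain carbon bound to an oxygen next to a carbonyl group and a saturated chain carbon), ethoxycarbonyl to isopropoxycarbonyl. Going by the values given here, one measured step bears on it, a modest one beyond the scatter that also adds methyl on the ester chain (a 2.6-fold lower number from compound 1 to compound 2 (0.41 log units; beyond the scatter)). On this single precedent, a smaller move to a lower number is expected in this assay (a 1.7-fold lower number from compound 2 to compound 3 (0.22 log units; within the scatter)). The estimate for compound 3 is 8000 nM (range 3500 nM to 20000 nM).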

Compound 3, half-maximal cytotoxic concentration: 8700 nM
Estimate against measurement, compound 3: 1.1-fold (0.04 log units) below; the range from low to high includes it.
By their numbers in this assay, from the lowest: compounds 3 and 2 (each within the scatter of the next); then compound 1.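

In this assay, ethoxycarbonyl to isopropoxycarbonyl gives a 1.5-fold lower number from compound 2 to compound 3 (0.18 log units; within the scatter) and so does not separate the two esters. Isopropyl in place of methyl on the oxygen gives a 3.9-fold lower number from compound 1 to compound 3 (0.59 log units; beyond the scatter) in the same test, which sets the methyl ester apart from the isopropyl ester. No supporting measurement bears on the cause of either step.

The series shown covers only the methyl, ethyl and isopropyl esters. From the compounds shown here alone, how a carboxylic acid, a primary amide or a longer chain at this place would read remains open.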